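Pyridin-4-yl for Furan-2-yl on the Benzylic Carbon

The source may report more compounds than this note shows. Statements on the series, on what has been measured and on what is new or still open speak of the compounds shown alone.

Compound 1 `COc1cc(/C=C/c2nc(Nc3ccc(C(F)(F)F)cc3)c3sccc3n2)cc(OC)c1OC`: 436000 nM
Compound 2 `COc1cc(/C=C/c2nc(NCc3ccccc3Cl)c3sccc3n2)cc(OC)c1OC`: > 1000000 nM, a limit of the assay
Compound 3 `COc1cc(/C=C/c2nc(NCc3ccco3)c3sccc3n2)cc(OC)c1OC`: 189000 nM

In a functional assay on L02 cells (Homo sapiens) for inhibition, read by Griess assay, with stated times of 1 h and 24 h (a lower number here means a stronger inhibitor, a higher number a weaker inhibitor), compound 3 gives the lowest of the two numbers. Compound 1 is nearest, with a 2.3-fold lower number from compound 1 to compound 3 (0.36 log units; beyond the scatter). Compound 2 sits at the limit of > 1000000 nM in this assay, at which 1 of the 3 values shown sits.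

Compound 4 `COc1cc(/C=C/c2nc(NCc3ccncc3)c3sccc3n2)cc(OC)c1OC` differs from compound 3 by pyridin-4-yl in place of furan-2-yl on a saturated chain carbon bound to a nitrogen on an aromatic ring. The step of an at least 5.2-fold lower number from compound 2 to compound 3 (0.72 log units; beyond the scatter) changed the same position and was at least modest, while an at least 2.2-fold higher number from compound 1 to compound 2 (0.36 log units; beyond the scatter) and a 2.3-fold lower number from compound 1 to compound 3 (0.36 log units; beyond the scatter) replaced the whole group with modest effect. A modest step in this assay is therefore expected, direction uncertain; compound 4 is estimated at 250000 nM, between 100000 nM and 700000 nM, meaning a 1.3-fold higher number from compound 3 to compound 4 (0.12 log units; within the scatter).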

Compound 4, half-maximal inhibitory concentration: 374000 nM
Compound 4: the middle estimate sits 1.5-fold (0.17 log units) below what was measured; the measured number falls inside the stated range.
By their numbers in this assay, from the lowest: compounds 3, 4 and 1 (each within the scatter of the next, the first and the last beyond it). At a limit, above all of these: compound 2.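

In this assay, a 2.0-fold higher number from compound 3 to compound 4 (0.30 log units; within the scatter), so at this saturated chain carbon a six-membered pyridin-4-yl ring and a five-membered furan-2-yl ring cannot be told apart. The 2-chlorophenyl group stands apart, with an at least 2.6-fold lower number from compound 2 to compound 4 (0.42 log units; beyond the scatter), while a 1.2-fold lower number from compound 1 to compound 4 (0.07 log units; within the scatter), so (pyridin-4-yl)methyl and 4-(trifluoromethyl)phenyl on the nitrogen also cannot be told apart. The figure for compound 2 is a limit, not a number: the limit of > 1000000 nM in this assay, at which 1 of the 4 values shown sits.

The compounds shown leave open whether a thiophen-2-yl ring, an unsubstituted phenyl ring or a saturated piperidin-4-yl ring on this carbon would give a clearly different number.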